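This account rests on a few compounds, and the source may have more. Where it says the series, first, only, none or still open, it means among the compounds named here.

Measured compounds:
compound 1, `OC[C@H]1O[C@@H](n2cnc3c(NCc4ccccc4Br)ncnc32)[C@H](O)[C@@H]1O`: 6600 nM
compound 2, `Cc1ccc(CNc2ncnc3c2ncn3[C@@H]2O[C@H](CO)[C@@H](O)[C@H]2O)cc1`: > 166000 nM, a limit of the assay
compound 3, `OC[C@H]1O[C@@H](n2cnc3c(NCc4ccc(F)cc4F)ncnc32)[C@H](O)[C@@H]1O`: 3400 nM

All three compounds share one core and differ only in the aromatic group on a saturated chain carbon bound to a nitrogen on an aromatic ring. In a functional assay on HL-60 cells (Homo sapiens) for antiproliferative activity, with a stated time of 72 h (a lower number here means a stronger inhibitor, a higher number a weaker inhibitor), compound 1 gives 6600 nM. Compound 3 gives 3400 nM, and the step of a 1.9-fold lower number from compound 1 to compound 3 (0.29 log units; within the scatter) lies within the scatter, so compound 1 and compound 3 sit together. Compound 2 reaches only a limit of the assay, > 166000 nM. The step of an at least 25-fold higher number from compound 1 to compound 2 (1.40 log units; beyond the scatter) is large and rests on (the limit of > 166000 nM in this assay, at which 1 of the 3 values shown sits).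

Compound 4, `Cc1cccc(CNc2ncnc3c2ncn3[C@@H]2O[C@H](CO)[C@@H](O)[C@H]2O)c1O`, is not yet measured. Its change from compound 1 is 2-hydroxy-3-methylphenyl in place of 2-bromophenyl on a saturated chain carbon bound to a nitrogen on an aromatic ring. Among the compounds with values here, two measured steps bear on it: the small step of a 1.9-fold lower number from compound 1 to compound 3 (0.29 log units; within the scatter) and the large step of an at least 25-fold higher number from compound 1 to compound 2 (1.40 log units; beyond the scatter). Within the data shown here, the entering group carries a methyl, as does the 4-methylphenyl of compound 2, and also a hydroxy that no measured compound carries. A step upward in this assay, toward a weaker inhibitor, is therefore expected for compound 4, though a smaller one than the step to compound 2: the expected step is a 3.8-fold higher number from compound 1 to compound 4 (0.58 log units; beyond the scatter). Compound 4 is estimated at 25000 nM, with a range from 6000 nM to 120000 nM.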

Compound 4, half-maximal inhibitory concentration: 15000 nM
Beside the measured number, compound 4's estimate is 1.7-fold (0.22 log units) above it; measured number inside the range.
By their numbers in this assay, from the lowest: compounds 3 and 1 (each within the scatter of the next); then compound 4. At a limit, above all of these: compound 2.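

In this assay, a methyl-bearing aromatic group at this position, on a saturated chain carbon bound to a nitrogen on an aromatic ring, can still give a measured number, and the cost of the change from the two earlier measured compounds is modest (a 2.3-fold higher number from compound 1 to compound 4 (0.36 log units; beyond the scatter) and a 4.4-fold higher number from compound 3 to compound 4 (0.64 log units; beyond the scatter)). Compound 2 stands at a limit of the assay, and the large step of an at least 11-fold lower number from compound 2 to compound 4 (1.04 log units; beyond the scatter) rests on that limit: the limit of > 166000 nM in this assay, at which 1 of the 4 values shown sits. A methyl on the aromatic group therefore does not by itself go with the loss seen for compound 2, since compound 4 also carries a methyl and goes against that reading, although it carries a hydroxy as well.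

The compounds shown leave open whether the hydroxy or the different place of the methyl separates compound 4 from compound 2, as 2-hydroxyphenyl and 3-methylphenyl do not appear on their own among them. Also open, as far as these compounds go, is how a methoxy or an amine on the aromatic group in place of the hydroxy would compare at this position.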